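Paw edema series: phenyl in place of allyl

This account rests on a few compounds, and the source may have more. Where it says the series, first, only, none or still open, it means among the compounds named here.

Measured so far:
compound 1 `COc1ccc(-c2nnc(SC/C(=N/O)c3ccccc3)n2-c2ccccc2)cc1`: 63%
compound 2 `COc1ccc(-c2nnc(SCC(=O)c3ccccc3)n2-c2ccccc2)cc1OC`: 59%
compound 3 `C=CCn1c(SCC(=O)c2ccccc2)nnc1-c1ccc(OC)cc1`: 63%

All three compounds were read in a functional assay on the whole organism (strain albino) for inhibition, with Rattus norvegicus as the target, read by paw edema, with a stated time of 3 h, at a dose of 0.28 mmol/kg by the oral route; on this read-out lower numbers stand for less inhibition and higher numbers for more inhibition at the one dose given (going by the name of the read-out). Compound 3 stands level with compound 1 at the digits reported, and together these two give the highest numbers of the three. The nearest neighbour of compound 3 is compound 1, with no change at the digits reported; the furthest is compound 2, whose number lies a little lower, still within the scatter. With so little spread, none of the three is set apart from the others on this read-out.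

Compound 4 `COc1ccc(-c2nnc(SCC(=O)c3ccccc3)n2-c2ccccc2)cc1` is not yet measured. It differs from compound 3 in one place: phenyl in place of allyl on an aromatic nitrogen. For the measured compounds named here, no pair of measured compounds isolates this change. Compound 4 carries the phenyl on the ring nitrogen as compound 2 does, and the 4-methoxyphenyl group as compound 3 does. Given that compound 2 gives 59% and compound 3 gives 63%, the expected step from compound 3 to compound 4 is a number 3 percentage points lower from compound 3 to compound 4 (within the scatter), which is no change beyond the scatter. For compound 4 in this assay the estimate is 60%, with a range from 50% to 70%.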

Compound 4, a percentage reported as inhibition, in the whole organism at one dose (the size of the read-out at that dose, not a potency): 58%
Beside the measured number, compound 4's estimate is 2 percentage points above it; measured number inside the range.
By their numbers in this assay, from the lowest: compounds 4, 2, 1 and 3 (each within the scatter of the next).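

In this assay, the swap of phenyl in place of allyl on an aromatic nitrogen, next to the ring atom that bears a 4-methoxyphenyl group, is now read directly as a number 5 percentage points lower from compound 3 to compound 4 (within the scatter), so this position takes an aromatic ring of 6 heavy atoms in place of an open chain of 3 with no change beyond the scatter. The two other single changes likewise stay inside the scatter: hydrogen in place of methoxy on an aromatic carbon gives a number 1 percentage points lower from compound 2 to compound 4 (within the scatter), and a group of 8 heavy atoms in place of a group of 9 heavy atoms, on a saturated chain carbon bound to a sulfur, gives a number 5 percentage points lower from compound 1 to compound 4 (within the scatter). Nothing available on these compounds offers an explanation for this flat result.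

Whether any group on this nitrogen moves the number beyond the scatter remains open, as the compounds shown hold only allyl and phenyl there, and a group such as a primary amine, a carboxylic acid or a longer chain has no reading here. With one dose and one time point, the shared level of these compounds also says nothing about how their potencies compare.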